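Para substituent on the benzyl amide: methoxy in place of fluoro

The source may report more compounds than this note shows. Statements on the series, on what has been measured and on what is new or still open speak of the compounds shown alone.

Measured compounds:
compound 1 `Cc1ccc(CNC(=O)CC2c3ccccc3N=C(N3CCN(CCN(C)C)CC3)N2c2ccc(-c3ccccc3)cc2)cc1`, 460 nM
compound 2 `CN(C)CCN1CCN(C2=Nc3ccccc3C(CC(=O)NCc3ccc(F)cc3)N2c2ccc(-c3ccccc3)cc2)CC1`, 320 nM

In an assay on HEK293 cells for inhibition of Voltage-dependent T-type calcium channel subunit alpha-1G (Homo sapiens), read by patch clamp (a higher number here means a weaker inhibitor, a lower number a stronger inhibitor), compound 1 gives 460 nM and compound 2 gives 320 nM. Within the data shown here, the single measured step is a 1.4-fold lower number from compound 1 to compound 2 (0.16 log units; within the scatter). Compound 2 thus stands at the smaller of the two numbers, but its gap to compound 1 is within the scatter, so the two are not separable.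

Compound 3 `COc1ccc(CNC(=O)CC2c3ccccc3N=C(N3CCN(CCN(C)C)CC3)N2c2ccc(-c3ccccc3)cc2)cc1` is not yet measured. It differs from compound 2 by methoxy in place of fluoro on an aromatic carbon. Among the measured compounds shown here, the only step bearing on this position, from compound 1 to compound 2, was within the scatter, so the two para groups examined so far gave no separable numbers. No step beyond the scatter is therefore expected in this assay for compound 3. Compound 3 is estimated at 400 nM, with a range from 150 nM to 1100 nM. The expected step is a 1.3-fold higher number from compound 2 to compound 3 (0.10 log units; within the scatter).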

Compound 3, half-maximal inhibitory concentration: 310 nM
Beside the measured number, compound 3's estimate is 1.3-fold (0.11 log units) above it; low and high end bracket the measured number.
By their numbers in this assay, from the lowest: compounds 3, 2 and 1 (each within the scatter of the next).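

In this assay, methoxy in place of fluoro gives a 1.0-fold lower number from compound 2 to compound 3 (0.01 log units; within the scatter), and methoxy in place of methyl gives a 1.5-fold lower number from compound 1 to compound 3 (0.17 log units; within the scatter), both within the scatter. Methyl, fluoro and methoxy on this aromatic carbon therefore give numbers that cannot be separated, and the series now includes a group with a hydrogen-bond acceptor and one more heavy atom than fluoro, still with no separable difference. Nothing available explains this flat result.

As far as these compounds go, it remains open whether an amine, a carboxylic acid or a longer alkoxy chain on this aromatic carbon would give a step beyond the scatter. From the compounds shown here alone, all three compounds share the rest of the structure, so it is also open whether the same flat result would hold on a different core.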